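The source may hold more compounds than are shown below. What is called first, only, known or untested is meant among the compounds shown, and "the series" means these compounds.

In a functional assay on NCI-H292 cells (Homo sapiens) for antiproliferative activity (a lower number here means a stronger inhibitor, a higher number a weaker inhibitor), compound 1 `Cc1ccc(N2C(=O)N/C(=C\c3ccc(O)cc3)C2=O)cc1` gives 27900 nM. Compound 2 `Cc1cccc(N2C(=O)N/C(=C\c3ccc(O)cc3)C2=O)c1` reaches only a limit of this assay, > 200000 nM. Compound 3 `O=C(O)c1cccc(N2C(=O)N/C(=C\c3ccc(O)cc3)C2=O)c1` likewise stops at a limit, > 200000 nM. Among the three, the only readable step is an at least 7.1-fold higher number from compound 1 to compound 2 (0.85 log units; beyond the scatter), whereas a step that the two limits leave unreadable from compound 2 to compound 3 cannot be sized because both of its ends sit at the limit of > 200000 nM in this assay, at which 2 of the 3 values shown sit. Compound 3 therefore stands at the weak end of what has been measured, with no number of its own, only a limit.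

Compound 4 `O=C1N/C(=C\c2ccc(O)cc2)C(=O)N1c1cccc(Br)c1` differs from compound 3 by bromo in place of carboxy on an aromatic carbon. Going by the values given here, two measured steps touch this position: an at least 7.1-fold higher number from compound 1 to compound 2 (0.85 log units; beyond the scatter) shows that a methyl on the ring in this place already drives the number to a limit, and a step that the two limits leave unreadable from compound 2 to compound 3 shows that exchanging that methyl for a carboxy left the value at a limit as well. Nothing measured tells how a bromo in this place behaves, so the step of an at least 1.3-fold lower number from compound 3 to compound 4 (0.12 log units; that floor lies within the scatter) is expected to be small or not readable. Compound 4 is thus estimated at 150000 nM in this assay, within a range from 30000 nM to 300000 nM, with a real chance that only a limit is reported.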

Compound 4, half-maximal inhibitory concentration: > 200000 nM
Compound 4 was reported as a limit; the forecaster's own chance of this, stated with the estimate: 55%; middle value at least 1.3-fold (0.12 log units) away from the limit.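

With bromo on this aromatic carbon, meta to a large group, compound 4 also ends at a limit in this assay. Methyl, carboxy and bromo at this place have thus all failed to give a number of their own, and the steps among compounds 2, 3 and 4 cannot be read: the limit of > 200000 nM in this assay, at which 3 of the 4 values shown sit. The one readable step is an at least 7.1-fold higher number from compound 1 to compound 4 (0.85 log units; beyond the scatter), with 3-bromophenyl in place of 4-methylphenyl, which leaves compound 1 as the only one of the four with a measured number.

The compounds shown leave open whether any other group at this place, such as an amine or a methoxy, would give a number rather than a limit, and whether the limits hide real differences among compounds 2, 3 and 4. Also open, going by these compounds, is how a 4-bromophenyl would compare with the 4-methylphenyl of compound 1, which would separate the change of group from the change of place that the step to compound 4 combines.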